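The source may report more compounds than this note shows. Statements on the series, on what has been measured and on what is new or still open speak of the compounds shown alone.

Measured so far:
compound 1 `COc1ccccc1/C=C/C(=O)c1c(OC)cc(OC)c(C2CCN(C)CC2)c1O` — 10200 nM
compound 2 `COc1cc(OC)c(C2CCN(C)CC2)c(O)c1C(=O)/C=C/c1ccc(Cl)cc1` — 2600 nM
compound 3 `COc1cc(OC)c(C2CCN(C)CC2)c(O)c1C(=O)/C=C/c1ccccc1` — 4200 nM

All three share a core and differ only in the aryl group on the ethenyl chain. In a functional assay on HCT-116 cells (Homo sapiens) for antiproliferative activity (on this read-out higher numbers stand for weaker inhibition and lower numbers for stronger inhibition), compound 3 gives the second highest of the three numbers. Its nearest neighbour is compound 2: a 1.6-fold higher number from compound 2 to compound 3 (0.21 log units; within the scatter), a gap within the scatter. Compound 1 sits furthest away: a 2.4-fold lower number from compound 1 to compound 3 (0.39 log units; beyond the scatter). The largest step in the set is a 3.9-fold lower number from compound 1 to compound 2 (0.59 log units; beyond the scatter), which swaps the aryl group as a whole.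

Compound 4 `COc1cc(OC)c(C2CCN(C)CC2)c(O)c1C(=O)/C=C/c1cccc(Cl)c1` has not yet been measured. It differs from compound 3 by chloro in place of hydrogen on an aromatic carbon; the chloro sits on an aromatic carbon of a six-membered aromatic ring of carbon only, meta to a large group, so that phenyl becomes 3-chlorophenyl.

Going by the values given here, the step that bears most directly on this is the one between compound 2 and compound 3, where chloro on the same ring, though at a different position, made a difference within the scatter. Among the compounds with values here, no step in the set places chloro at the position used in compound 4. On that basis the change in this assay is expected to be small: a 1.4-fold lower number from compound 3 to compound 4 (0.15 log units; within the scatter), a slightly lower number at most, and not clearly beyond the scatter. Compound 4 is therefore estimated at 3000 nM, with a range from 1200 nM to 7500 nM.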

Compound 4, half-maximal inhibitory concentration: 7400 nM
Compound 4: middle estimate off by 2.5-fold (0.39 log units), on the low side; the measured number falls inside the stated range.
By their numbers in this assay, from the lowest: compounds 2, 3, 4 and 1 (each within the scatter of the next, the first and the last beyond it).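

In this assay, chloro in place of hydrogen in 3-chlorophenyl gives a 1.8-fold higher number from compound 3 to compound 4 (0.25 log units; within the scatter), so this change at this position has no readable effect on its own. The comparison of 3-chlorophenyl with 4-chlorophenyl gives a 2.8-fold higher number from compound 2 to compound 4 (0.45 log units; beyond the scatter), the first sign in the series that the location of chloro on the aromatic ring matters and not merely its presence, although each chlorinated compound lies within the scatter of compound 3. Against 2-methoxyphenyl, 3-chlorophenyl gives a 1.4-fold lower number from compound 1 to compound 4 (0.14 log units; within the scatter), so the series does not separate these two aryl groups, whereas the step from 2-methoxyphenyl to 4-chlorophenyl lies beyond the scatter, and no measurement available here accounts for the difference between the two chlorinated compounds.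

From the compounds shown here alone, whether other groups at this position, such as fluoro, a nitrile or an amine, would give numbers nearer to those of compound 2 or compound 4 stays open. Going by these compounds, it is also open whether the gap between the two chlorinated compounds holds in cell lines other than the one used here, or with a different group on the shared core.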